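The source may report more compounds than this note shows. Statements on the series, on what has been measured and on what is new or still open speak of the compounds shown alone.

Of the compounds shown here, three have so far been measured in an assay on T-REx-293 cells for inhibition of potassium channel subfamily T member 1 (Homo sapiens), read by patch clamp; a higher number here means a weaker inhibitor, a lower number a stronger inhibitor. Compound 1 `C[C@H](NC(=O)c1cc(C2CC2)nn1C)c1nc(-c2ccccc2)no1` gives 11400 nM. Compound 2 `Cc1cccc(-n2cc(C(C)NC(=O)c3cc(C(F)(F)F)nn3C)cn2)c1` gives 1600 nM. Compound 3 `Cc1cc(-c2noc([C@H](C)NC(=O)c3cc(C(F)(F)F)nn3C)n2)ccn1` gives 165 nM, the lowest number of the three; its gaps to compound 2 and to compound 1 both lie beyond the scatter, so compound 3 stands as the strongest inhibitor of the measured set. No two of these compounds differ in a single place, so no isolated structural step can be read from the numbers.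

Compound 4 `CO[C@H](C)c1cc(-c2noc([C@H](C)NC(=O)c3cc(C(F)(F)F)nn3C)n2)ccn1` has not yet been measured. It differs from compound 3 in one place: 1-methoxyethyl in place of methyl on an aromatic carbon. The measured compounds contain nothing that shows what such an enlargement does, so the expectation rests on the starting point alone. With the rest of compound 3 left unchanged, a small shift toward a higher number, or none beyond the scatter, is the working assumption. Compound 4 is expected to give about 250 nM, within 80 nM to 800 nM. The estimate implies a 1.5-fold higher number from compound 3 to compound 4 (0.18 log units; within the scatter) as the expected step.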

Compound 4, half-maximal inhibitory concentration: 778 nM
Compound 4: the middle estimate sits 3.1-fold (0.49 log units) below what was measured; measured number inside the range.
By their numbers in this assay, from the lowest: compound 3; then compound 4; then compound 2; then compound 1.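

In this assay, 1-methoxyethyl in place of methyl on the aromatic carbon next to the ring nitrogen gives a 4.7-fold higher number from compound 3 to compound 4 (0.67 log units; beyond the scatter). Going by these compounds alone, this is the first single-place change, and it shows that the number at this position responds to the group placed there; the step is modest, so the enlargement weakens inhibition without abolishing it. Nothing available separates the contributions of the added carbons, the ether oxygen and the new stereocentre, and no measurement gives a cause for the step.

Open, on these data alone, is whether the oxygen matters at all: an isopropyl group here would keep a branched chain without it, while a methoxy group would keep the oxygen on a shorter chain. As far as these compounds go, the effect of the opposite configuration of the 1-methoxyethyl stereocentre also remains unknown.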